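A few compounds are considered here, and "the series" means these few. Any claim that something is new, unique, unknown or untested is made for them only; others in the source may bear on it.

Compound 1, `CCCNc1nc(N)nc2ccccc12`: > 25000 nM in an ADME assay on HEK293 cells (Homo sapiens) for cytotoxicity, with a stated time of 6 h; a higher number here means that more compound is tolerated, a lower number that less compound is tolerated. Compound 2, `CCCCNc1nc(N)nc2cccc(Cl)c12`: 100 nM.

Of the compounds shown here, two sharing one core have been tested so far. Compound 1 sits at the limit of > 25000 nM in this assay, at which 1 of the 2 values shown sits, and that value is a limit of the measurement rather than a number. Among the measured compounds shown here, compound 2 is thus the only compound with a definite number, and in this assay compound 2 gives 100 nM. The next compound, compound 3 with structure `CCCCNc1nc(N)nc2cccc(C(=O)NC(C)C)c12`, has not yet been measured. It differs from compound 2 in a single exchange: isopropylcarbamoyl in place of chloro on an aromatic carbon. For the measured compounds named here, no measured step between two compounds that differ in one place is available, so the size of this change can only be estimated. The expected step from compound 2 to compound 3 in this assay is a 10-fold higher number from compound 2 to compound 3 (1.00 log units; beyond the scatter), towards more compound being tolerated and beyond the usual scatter. Compound 3 is accordingly expected to give 1000 nM in this assay, with a likely range from 200 nM to 10000 nM.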

Compound 3, half-maximal cytotoxic concentration: > 25000 nM
Compound 3 ended at the assay's limit; the forecaster's own chance of this, stated with the estimate: 15%; at least 25-fold (1.39 log units) between middle value and limit.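

On an aromatic carbon that is ortho to a fused ring and meta to a fused ring, exchanging chloro for isopropylcarbamoyl gives an at least 250-fold higher number from compound 2 to compound 3 (2.39 log units; beyond the scatter) in this assay. Among the compounds shown here, this is the first measured change in a single place, and it shows that this one position can carry the whole distance from a definite number to the end of the measurable range. The step is only a minimum, because the value of compound 3 is a limit and not a number: the limit of > 25000 nM in this assay, at which 2 of the 3 values shown sit.

From the compounds shown here alone, how much more compound 3 would be tolerated remains unknown. Going by these compounds, it is also open whether the amide is needed for this change, or whether a plain methyl, a methoxy group or a carboxylic acid at the same place would shift the number as far.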